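Pyridin-3-yl replaces pyrazin-2-yl at a clearance limit

The compounds below may be only part of what the source reports. "The series", "measured", "known", "first", "only" and "open" are said of these compounds alone.

In an in vitro ADME assay on microsomes from liver (Homo sapiens) for metabolic stability (a lower number here means slower removal, a higher number faster removal of the compound), the measured compounds stand as follows:
- Compound 1 `COc1ccc(-c2ccccn2)c2cc(C(=O)Nc3ccncc3)oc12` gives 37.2 mL/min/kg
- Compound 2 `COc1ccc(-c2cnccn2)c2cc(C(=O)Nc3ccncc3)oc12` gives 154 mL/min/kg
- Compound 3 `COc1ccc(-c2cnccn2)c2cc(C(=O)Nc3ccc(Cn4ccnc4)cc3)oc12` gives < 7.84 mL/min/kg

Compound 3 reports only a limit and not a number (the limit of < 7.84 mL/min/kg in this assay, at which 1 of the 3 values shown sits). Compound 4 `COc1ccc(-c2cccnc2)c2cc(C(=O)Nc3ccc(Cn4ccnc4)cc3)oc12` differs from it by pyridin-3-yl in place of pyrazin-2-yl on an aromatic carbon, para to a methoxy group (pyridin-3-yl in place of pyrazin-2-yl on an aromatic carbon). Among the compounds with values here, one measured step bears on this change, the move from pyridin-2-yl to pyrazin-2-yl (a 4.1-fold higher number from compound 1 to compound 2 (0.62 log units; beyond the scatter)). Read in reverse, that step points to no rise on leaving pyrazin-2-yl. It is only a loose guide, however, since compound 1 and compound 2 carry a different amide part from compound 3, and pyridin-3-yl is not pyridin-2-yl. A value close to the limit is therefore expected, with no large change in either direction. The expected step is a step that the limit leaves unreadable from compound 3 to compound 4 in this estimate. For compound 4 the estimate is 7 mL/min/kg (expected range 3.5 mL/min/kg to 20 mL/min/kg).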

Compound 4, clearance: 53 mL/min/kg
Estimate against measurement, compound 4: 7.6-fold (0.88 log units) below; the whole stated range lies below it.
By their numbers in this assay, from the lowest: compounds 1 and 4 (each within the scatter of the next); then compound 2. At a limit, below all of these: compound 3.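

The aromatic carbon para to a methoxy group also matters in this assay with a different amide part: pyridin-3-yl in place of pyrazin-2-yl gives an at least 6.7-fold higher number from compound 3 to compound 4 (0.82 log units; beyond the scatter). Within the data shown here, the one earlier step at this carbon pointed the other way for pyrazin-2-yl, which brought a 4.1-fold higher number from compound 1 to compound 2 (0.62 log units; beyond the scatter), so pyrazin-2-yl carries the higher number in one pair and the lower number in the other. The new step is open at its upper end, and the value it starts from is a limit: the limit of < 7.84 mL/min/kg in this assay, at which 1 of the 4 values shown sits.

The compounds shown cannot separate the effect of the amide part from the difference between pyridin-2-yl and pyridin-3-yl, as no single ring is compared on both amide parts. As far as these compounds go, how a pyrimidin-5-yl ring, or a pyridine ring carrying an amine, would read at this carbon also stays open.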